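Two Compounds at a Limit, a Third to Come

The source may report more compounds than this note shows. Statements on the series, on what has been measured and on what is new or still open speak of the compounds shown alone.

Measured so far:
compound 1, `O=C(NCc1ccccc1)[C@@H]1CCC(=O)N1Cc1ccccc1`: > 5000 nM
compound 2, `O=C(O)c1ccc(COc2ccc(CNC(=O)[C@@H]3CCC(=O)N3Cc3ccc(C(F)(F)F)cc3)cc2)cc1`: > 5000 nM

In an assay on HEK293 cells for inhibition of Ataxin-2 (Mus musculus), read by fluorescence and Amplex Red (a higher number here means a weaker inhibitor, a lower number a stronger inhibitor), compound 1 gives > 5000 nM, which is a limit of the assay rather than a number. Compound 2 likewise gives > 5000 nM, again a limit and not a number. Among the measured compounds shown here, both values sit at the limit of > 5000 nM in this assay, at which 2 of the 2 values shown sit, so compound 1 stands nowhere on a scale: no measured step exists between these two compounds, and nothing shows whether either inhibits at all.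

Compound 3, `O=C(NCc1ccc(OCc2ccc(B(O)O)cc2)cc1)[C@@H]1CCC(=O)N1Cc1ccccc1`, has not yet been measured. It differs from compound 1 by a group of 11 heavy atoms (7 carbon, 1 boron, 3 oxygen; one six-membered aromatic ring of carbon only) in place of a hydrogen atom, on an aromatic carbon. Compound 2, which also extends the core with a large aromatic group, gives > 5000 nM, a limit. On that basis compound 3 is expected to behave the same way. The step expected from compound 1 to compound 3 is a step that the limit leaves unreadable from compound 1 to compound 3, that is, nothing beyond the scatter. For compound 3 the estimated value is 8000 nM, with a range from 3000 nM to 30000 nM, and most likely another limit.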

Compound 3, half-maximal inhibitory concentration: 35 nM
Compound 3: the middle estimate sits 230-fold (2.36 log units) above what was measured; the measured number lies below the stated range.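

Compound 1 gives > 5000 nM in this assay, which is a limit of the assay and not a number. The step can still be read, as an at least 140-fold lower number from compound 1 to compound 3 (2.15 log units; beyond the scatter), so this aromatic carbon, para to a large group, can carry a group of this size and the change can turn a compound at the limit into one with a measured value. Compound 3 is the only one of the three with a number rather than a limit, and that gives the series its first real point on the scale: the limit of > 5000 nM in this assay, at which 2 of the 3 values shown sit.

The compounds shown leave open which part of the entering group accounts for the step, its aromatic ring or its boron atom. An amine or a nitrile standing where the boron sits would help to tell these two apart.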